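Arylamino in place of dipropylamino on the shared core

A few compounds are considered here, and "the series" means these few. Any claim that something is new, unique, unknown or untested is made for them only; others in the source may bear on it.

In a functional assay on MGC-803 cells (Homo sapiens) for inhibition, read by sulforhodamine B assay (on this read-out higher numbers stand for weaker inhibition and lower numbers for stronger inhibition), compound 1 (`O=C1C=C(NCc2ccccc2)C(=O)c2c1nc1n2[C@H]2OC[C@@H](O)[C@H]2OC1`) gives 2670 nM and compound 2 (`CCOc1ccccc1NC1=CC(=O)c2nc3n(c2C1=O)[C@H]1OC[C@@H](O)[C@H]1OC3`) gives 2450 nM. From the compounds shown here alone, compound 3 (`CCCN(CCC)C1=CC(=O)c2nc3n(c2C1=O)[C@H]1OC[C@@H](O)[C@H]1OC3`) gives only a limit, > 16000 nM, and no number, so its true position is unknown.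

Compound 4 (`O=C1C=C(Nc2cccc(Cl)c2)C(=O)c2c1nc1n2[C@H]2OC[C@@H](O)[C@H]2OC1`) carries (3-chlorophenyl)amino in place of dipropylamino on a double-bonded ring carbon.

Going by the values given here, two measured steps bear on this change. Dipropylamino entering at the same place for benzylamino gives an at least 5.9-fold higher number from compound 1 to compound 3 (0.77 log units; beyond the scatter), which lies beyond the scatter. Exchanging benzyl for 2-ethoxyphenyl on the amine nitrogen gives a 1.1-fold lower number from compound 1 to compound 2 (0.04 log units; within the scatter), which lies within it. Neither measured compound with an aromatic ring on that nitrogen carries chlorine, so the reading for compound 4 is an extrapolation. Leaving dipropylamino is therefore expected to reverse roughly the first step, and the return should land near compound 1 at 2670 nM. The expected change is an at least 6.9-fold lower number from compound 3 to compound 4 (0.84 log units; beyond the scatter). Compound 4 is estimated at 2300 nM, with an expected range of 750 nM to 7500 nM.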

Compound 4, half-maximal inhibitory concentration: 1770 nM
Compound 4: middle estimate off by 1.3-fold (0.11 log units), on the high side; the measured number falls inside the stated range.
By their numbers in this assay, from the lowest: compounds 4, 2 and 1 (each within the scatter of the next). At a limit, above all of these: compound 3.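

In this assay, 3-chlorophenyl on the amine nitrogen sits level with both earlier groups there: a 1.4-fold lower number from compound 2 to compound 4 (0.14 log units; within the scatter), and a 1.5-fold lower number from compound 1 to compound 4 (0.18 log units; within the scatter). Chlorine on an aromatic ring at this nitrogen, new with compound 4, therefore leaves the read-out within the scatter of compounds 1 and 2. The step away from dipropylamino reads an at least 9.0-fold lower number from compound 3 to compound 4 (0.95 log units; beyond the scatter), and it is only a bound, its starting point being a limit and not a number: the limit of > 16000 nM in this assay, at which 1 of the 4 values shown sits.

Compound 3 alone lacks a hydrogen on this nitrogen and also alone lacks an aromatic ring, so the compounds shown cannot separate the two features. Propylamino at the same ring carbon, with one propyl chain and the hydrogen kept, would pull them apart.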